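Swapping the bicyclic ring on the anilino nitrogen

This account rests on a few compounds, and the source may have more. Where it says the series, first, only, none or still open, it means among the compounds named here.

Measured compounds:
compound 1, `CCN(CC)c1nc(Nc2cccc(F)c2)nc(OC(C(F)(F)F)C(F)(F)F)n1` — 140 nM
compound 2, `CCN(CC)c1nc(Nc2cccc(Cl)c2)nc(OC(C(F)(F)F)C(F)(F)F)n1` — 2800 nM
compound 3, `CCN(CC)c1nc(Nc2ccc3cn[nH]c3c2)nc(OC(C(F)(F)F)C(F)(F)F)n1` — 900 nM

All three share one core and differ only in the aromatic group attached to the anilino nitrogen. In an assay on cells for activation of Cystic fibrosis transmembrane conductance regulator (Homo sapiens), read by fluorescence, with stated times of 10 min and 12 s (a higher number here means that more compound is needed for the effect, a lower number that less compound is needed), compound 3 gives 900 nM, the second highest of the three numbers; it sits closer to compound 2, with a 3.1-fold lower number from compound 2 to compound 3 (0.49 log units; beyond the scatter), and further from compound 1, with a 6.4-fold higher number from compound 1 to compound 3 (0.81 log units; beyond the scatter).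

Compound 4, `CCN(CC)c1nc(Nc2ccc3ncsc3c2)nc(OC(C(F)(F)F)C(F)(F)F)n1`, has not yet been measured. The change from compound 3 is 1,3-benzothiazol-6-yl in place of 1H-indazol-6-yl on a nitrogen on an aromatic ring. Among the measured compounds shown here, no measured step makes exactly this kind of exchange, so the best guide is how much the group on this nitrogen has moved the numbers so far: a 20-fold higher number from compound 1 to compound 2 (1.30 log units; beyond the scatter) and a 6.4-fold higher number from compound 1 to compound 3 (0.81 log units; beyond the scatter) show that even small edits at this position can shift the result beyond the scatter, in either direction.

Since the bicyclic ring is retained and only its hetero atoms and donor are changed, a modest step in this assay is expected, more likely upward than downward, but the direction is uncertain. The estimated step is a 2.0-fold higher number from compound 3 to compound 4 (0.30 log units; within the scatter). For compound 4 the expected value is 1800 nM, with a range from 500 nM to 6000 nM.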

Compound 4, half-maximal effective concentration: 50 nM
Compound 4: middle estimate off by 36-fold (1.56 log units), on the high side; the measured number lies below the stated range.
By their numbers in this assay, from the lowest: compound 4; then compound 1; then compound 3; then compound 2.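

In this assay, the step to the 1,3-benzothiazol-6-yl group is large, with an 18-fold lower number from compound 3 to compound 4 (1.26 log units; beyond the scatter), so two bicyclic groups with the same number of heavy atoms and the same ring types are far from interchangeable on this nitrogen. The bicyclic shape itself is therefore no handicap here: the same group gives a 56-fold lower number from compound 2 to compound 4 (1.75 log units; beyond the scatter) and also a 2.8-fold lower number from compound 1 to compound 4 (0.45 log units; beyond the scatter), which makes compound 4 the most potent of the four, a place that compound 1 with its 3-fluorophenyl group held until now. Nothing shown explains why this exchange matters so much.

This single exchange changes several things at once, as sulfur enters the ring, a ring nitrogen is lost and the hydrogen-bond donor of the 1H-indazol-6-yl group disappears, so the contribution of each remains unresolved. A 1,3-benzoxazol-6-yl group, with oxygen in place of the sulfur, or a methyl group on the ring nitrogen of the 1H-indazol-6-yl group would help separate these changes, and the compounds shown say nothing about either.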